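Chain-linked basic ring variations on the shared core

The source may hold more compounds than are shown below. What is called first, only, known or untested is meant among the compounds shown, and "the series" means these compounds.

Measured so far:
- compound 1 `c1ccc2c(c1)CN[C@@H](CN(CC1CCNCC1)[C@H]1CCCc3cccnc31)C2`: 65 nM
- compound 2 `c1ccc2c(c1)CN[C@@H](CN(CCC1CCNCC1)[C@H]1CCCc3cccnc31)C2`: 150 nM
- compound 3 `CN1CCN(CCCN(C[C@H]2Cc3ccccc3CN2C)[C@H]2CCCc3cccnc32)CC1`: 536 nM

In a functional assay on CCRF-CEM cells for antagonist activity at C-X-C chemokine receptor type 4 (Homo sapiens), read by calcium flux, with stated times of 25 min and 90 s (on this read-out lower numbers stand for stronger inhibition and higher numbers for weaker inhibition), compound 2 gives 150 nM, the second highest number of the three; compound 1 sits nearest with 65 nM, compound 3 furthest with 536 nM. Among the measured compounds shown here, the one step counted within the set, a 2.3-fold higher number from compound 1 to compound 2 (0.36 log units; beyond the scatter), shows that lengthening the link between the amine nitrogen and the basic ring by one carbon moves the number upward by a modest, but real, amount.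

Compound 4 `c1ccc2c(c1)CN[C@@H](CN(CCCN1CCN(C3CC3)CC1)[C@H]1CCCc3cccnc31)C2` carries (4-cyclopropylpiperazin-1-yl)methyl in place of piperidin-4-yl on a saturated chain carbon, two bonds along the chain from an amine nitrogen. For the measured compounds named here, this again lengthens the link to the terminal ring and exchanges the ring itself, so the step from compound 1 to compound 2 is the closest precedent; compound 3, which also carries a three-carbon link to a two-nitrogen ring, differs from compound 2 in more than one place and gives no counted step, yet its value lies well above that of compound 2. On that basis a further modest rise is expected in this assay, a 1.9-fold higher number from compound 2 to compound 4 (0.27 log units; within the scatter), with wide uncertainty. Compound 4 is therefore estimated at 280 nM, within 90 nM to 900 nM.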

Compound 4, half-maximal inhibitory concentration: 50 nM
The estimate for compound 4 lay 5.6-fold (0.75 log units) above the measured number, outside the stated range (below it).
By their numbers in this assay, from the lowest: compounds 4 and 1 (each within the scatter of the next); then compound 2; then compound 3.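

In this assay, (4-cyclopropylpiperazin-1-yl)methyl in place of piperidin-4-yl on a saturated chain carbon, two bonds along the chain from an amine nitrogen, gives a 3.0-fold lower number from compound 2 to compound 4 (0.48 log units; beyond the scatter), so this position accepts the larger group, which has no hydrogen-bond donor, without loss. Against the shorter piperidin-4-yl chain, the larger group gives a 1.3-fold lower number from compound 1 to compound 4 (0.11 log units; within the scatter), which places the two within the scatter, so the rise in a 2.3-fold higher number from compound 1 to compound 2 (0.36 log units; beyond the scatter) does not extend to longer groups in general, and compound 4 goes against it. Nothing available bears on why the number falls with this exchange.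

The compounds shown do not separate the contribution of the cyclopropyl group from that of the piperazine ring. Morpholin-4-yl or 4-isopropylpiperazin-1-yl at this place would help to divide the two.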